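From 6-fluoropyridin-3-yl to 6-aminopyridin-3-yl: working notes

The compounds below may be only part of what the source reports. "The series", "measured", "known", "first", "only" and "open" are said of these compounds alone.

Measured so far in a functional assay on HCT-116 cells (Homo sapiens) for cytotoxicity, read by MTT assay, with a stated time of 72 h (a lower number here means a stronger inhibitor, a higher number a weaker inhibitor), are two compounds:
compound 1 `Nc1ccccc1NC(=O)c1ccc(NC(=O)NCc2cccnc2)cc1` gives 9400 nM
compound 2 `Nc1ccccc1NC(=O)c1ccc(NC(=O)NCc2ccc(F)nc2)cc1` gives 14000 nM

Going by the values given here, compound 2 stands within the scatter of compound 1, the only other measured compound: a 1.5-fold higher number from compound 1 to compound 2 (0.17 log units; within the scatter) for fluoro in place of hydrogen on an aromatic carbon.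

Compound 3 `Nc1ccc(CNC(=O)Nc2ccc(C(=O)Nc3ccccc3N)cc2)cn1` has not been measured. It carries amino in place of fluoro on an aromatic carbon of a six-membered aromatic ring with 1 nitrogen, next to the ring nitrogen and para to a large group, so 6-fluoropyridin-3-yl becomes 6-aminopyridin-3-yl (amino in place of fluoro on an aromatic carbon).

Among the compounds with values here, only the one measured step bears on this change, and it concerns hydrogen and fluoro. Within the data shown here, no amino compound has been measured. No step beyond the scatter is expected in this assay because a 1.5-fold higher number from compound 1 to compound 2 (0.17 log units; within the scatter) is all the series shows, which is thin ground. The estimate means a 1.4-fold lower number from compound 2 to compound 3 (0.15 log units; within the scatter) as the expected step. Compound 3 is estimated at 10000 nM with 4000 nM to 25000 nM as the expected range.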

Compound 3, half-maximal inhibitory concentration: 7300 nM
Compound 3: the middle estimate sits 1.4-fold (0.14 log units) above what was measured, and the stated range covers the measured number.
By their numbers in this assay, from the lowest: compounds 3, 1 and 2 (each within the scatter of the next).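

In this assay, the carbon next to the ring nitrogen and para to a large group has now carried hydrogen, fluoro and amino, and neither new step leaves the scatter: a 1.9-fold lower number from compound 2 to compound 3 (0.28 log units; within the scatter) and a 1.3-fold lower number from compound 1 to compound 3 (0.11 log units; within the scatter). Compared with the earlier hydrogen-to-fluoro step, this adds a substituent of a different count, since amino brings one hydrogen-bond donor and one hydrogen-bond acceptor where fluoro has none, and the three compounds still cannot be ordered at this position. No measured information is available to explain how these compounds relate in this cellular read-out.

The compounds shown leave open whether a larger group on the same carbon, such as methoxy, dimethylamino or a carboxylic acid, would give a step beyond the scatter in this assay. They also leave open whether the amino result would hold with a longer chain in place of the methylene link between the pyridine and the urea, as that part stays the same in all three compounds.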